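The source may hold more compounds than are shown below. What is called first, only, known or untested is meant among the compounds shown, and "the series" means these compounds.

Series notes. The shared core of compound 1 `CCCNc1nc(N)c(C(=O)N=C(N)N)nc1Cl` carries an amino group, a chloro group and an acylguanidine; the point of variation is the remaining ring carbon. In an assay for inhibition of acid-sensing ion channel 3 (Homo sapiens), read by patch clamp, tested at 20 uM (a lower number here means less inhibition, a higher number more inhibition at the concentration tested (going by the name of the read-out)), compound 1 gives 91%. Going by the values given here, compound 2 `NC(N)=NC(=O)c1nc(Cl)c(Nc2ccccn2)nc1N` replaces the propylamino substituent by a pyridin-2-ylamino group, and in this assay compound 2 gives 25%; the step of a number 66 percentage points lower from compound 1 to compound 2 (beyond the scatter) is the only measured comparison in the set.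

Compound 3 `NC(N)=NC(=O)c1nc(Cl)c(Sc2ccccc2)nc1N` carries a phenylsulfanyl group at the same ring carbon. In this assay compound 3 is recorded as "not determined" (no result reported), so it stands without a number and offers no anchor for the next step.

Compound 4 `NC(N)=NC(=O)c1nc(Cl)c(Oc2ccccc2)nc1N` differs from compound 3 as follows: phenoxy in place of phenylsulfanyl on an aromatic carbon. Among the compounds with values here, no measured step bears on a phenylsulfanyl-to-phenoxy exchange, and the step from compound 1 to compound 2 concerns a different kind of substituent, so no direction can be inferred from it. The measured values only bracket what the series has shown so far, from strong to weak inhibition.

Compound 4 is therefore expected to give about 50% in this assay, with a wide estimated range from 15% to 85%.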

Compound 4, a percentage reported as inhibition, at one concentration (the size of the read-out at that concentration, not a potency): 90%
Estimate against measurement, compound 4: 40 percentage points below; measured number above the stated range.
By their numbers in this assay, from the lowest: compound 2; then compounds 4 and 1 (each within the scatter of the next).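

In this assay, an aromatic ring at this ring carbon is compatible with strong inhibition: the step of a number 65 percentage points higher from compound 2 to compound 4 (beyond the scatter) recovers nearly all of the drop seen with the pyridin-2-ylamino group, so that drop cannot be attributed to the presence of an aromatic ring alone. The step of a number 1 percentage points lower from compound 1 to compound 4 (within the scatter) leaves phenoxy and propylamino inseparable here, which shows that this position accepts a nitrogen-linked chain and an oxygen-linked aromatic ring alike, while compound 2 goes against any simple reading that all substituents are equivalent. No available evidence accounts for these differences.

With no number for compound 3, the exchange of phenylsulfanyl for phenoxy cannot be read. Still open, on these data alone, is whether the low value of compound 2 follows from its ring nitrogen or its amino link, which a phenylamino group would help separate, and whether a propoxy group would behave like propylamino or like phenoxy.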